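A few compounds are considered here, and "the series" means these few. Any claim that something is new, unique, unknown or untested is made for them only; others in the source may bear on it.

Working notes on the series. Within the data shown here, compound 3 `c1ccc(COc2cccc(-c3cn([C@@H]4CN5CCC4CC5)nn3)c2)cc1` gives the lowest of the three numbers so far in an assay on HEK293 cells for displacement of a labelled ligand from Neuronal acetylcholine receptor; alpha3/beta4 (Homo sapiens), read by scintillation counting, with a stated time of 120 min; on this read-out higher numbers stand for weaker inhibition and lower numbers for stronger inhibition: compound 3 gives 6.67 nM. Compound 1 `Fc1ccc(-c2cn(C3CN4CCC3CC4)nn2)cc1` gives 8.5 nM in this assay, and the two values lie within the scatter of each other. Among the measured compounds shown here, compound 2 `c1ccc(COc2cccc(-c3cn([C@H]4CN5CCC4CC5)nn3)c2)cc1` gives 631 nM in this assay, and the step of a 95-fold lower number from compound 2 to compound 3 (1.98 log units; beyond the scatter) is the only one recorded among measured pairs; it rests on (the fact that one of compounds 2 and 3 is drawn with a defined configuration and the other without, at the place where they differ).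

Compound 4 `FCCCOc1cccc(-c2cn([C@@H]3CN4CCC3CC4)nn2)c1` differs from compound 3 by 2-fluoroethyl in place of phenyl on a saturated chain carbon bound to an oxygen on an aromatic ring. For the measured compounds named here, no measured step bears on this change: the one recorded step concerns a stereocentre, not the group on the oxygen. Compound 1 carries no group on an oxygen at all, so its value next to that of compound 3 only shows that both lie in the same region. With nothing to anchor the direction, the expectation is a step no larger than the scatter, written as a 2.1-fold higher number from compound 3 to compound 4 (0.32 log units; beyond the scatter), with a wide range to reflect the lack of evidence. Compound 4 is therefore estimated at 14 nM in this assay, between 3 nM and 70 nM.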

Compound 4, inhibition constant: 19.5 nM
The estimate for compound 4 lay 1.4-fold (0.14 log units) below the measured number, within the range that was stated.
By their numbers in this assay, from the lowest: compounds 3 and 1 (each within the scatter of the next); then compound 4; then compound 2.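

In this assay, among these compounds, the step of a 2.9-fold higher number from compound 3 to compound 4 (0.47 log units; beyond the scatter) gives the first reading at the group on the oxygen, where the earlier compounds varied only in the stereocentre or lacked such a group. With the configuration of compound 3 kept, replacing benzyloxy by 3-fluoropropoxy removes the aromatic ring and costs only a modest step, so a ring at this place is not needed for a value in the nanomolar range. No available evidence accounts for this step, since the only recorded explanation concerns the stereocentre rather than the group on the oxygen.

The compounds shown do not separate the loss of the ring from the entry of fluorine, which a plain propyl chain would address. As far as these compounds go, a longer chain, a terminal amine or a pyridine ring at this place also remains open, as does whether the stereocentre step carries over to the 3-fluoropropoxy compounds.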